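Compound 4: carboxy gives way to (methoxycarbonyl)methyl

The source may report more compounds than this note shows. Statements on the series, on what has been measured and on what is new or still open speak of the compounds shown alone.

- compound 1 `CCN(CC)C(=O)Cn1c(=O)c(-c2ccc(OC)cc2)cc2c(OC)cc(OC)cc21`: 10000 nM
- compound 2 `COc1ccc(-c2cc3c(OC)cc(OC)cc3n(CCCC#N)c2=O)cc1`: 10000 nM
- compound 3 `COc1ccc(-c2cc3c(OC)cc(OC)cc3n(CC(=O)O)c2=O)cc1`: 10000 nM

In a functional assay on PC-3 cells (Homo sapiens) for cytotoxicity, read by colorimetric assay and MTT assay (on this read-out lower numbers stand for stronger inhibition and higher numbers for weaker inhibition), compound 3 gives 10000 nM, the same number as compound 1 and compound 2. It therefore stands level with both, and nothing in this small set reads as stronger or weaker.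

The next compound, compound 4 `COC(=O)CCn1c(=O)c(-c2ccc(OC)cc2)cc2c(OC)cc(OC)cc21`, differs from compound 3 in one place: (methoxycarbonyl)methyl in place of carboxy on a saturated chain carbon bound to an aromatic nitrogen. In words, (methoxycarbonyl)methyl takes the place of carboxy on a saturated chain carbon bound to an aromatic nitrogen.

Within the data shown here, three measured steps bear on this change, since each swaps one side-chain group for another: no change at the digits printed from compound 1 to compound 2 (within the scatter), no change at the digits printed from compound 1 to compound 3 (within the scatter) and no change at the digits printed from compound 2 to compound 3 (within the scatter). None of them moved the number, even though the groups exchanged were quite different. Among the measured compounds shown here, no measured compound carries the new group, however, so a shift towards lower numbers cannot be excluded. On the evidence of those three steps, no step beyond the scatter is expected in this assay.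

The expected outcome is no change at the digits printed from compound 3 to compound 4 (within the scatter).

For compound 4 the estimated value is 10000 nM, with an expected range from 3000 nM to 20000 nM.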

Compound 4, half-maximal inhibitory concentration: 10000 nM
Compound 4: the middle estimate sits on the measured number at the digits printed; measured number inside the range.
By their numbers in this assay, from the lowest: compounds 1, 2, 3 and 4 (each within the scatter of the next).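

Carboxy and (methoxycarbonyl)methyl differ in what they bring to this place, a saturated chain carbon bound to an aromatic nitrogen: the entering group has 5 heavy atoms against 3 and 0 hydrogen-bond donors against 1, yet this assay shows no change at the digits printed from compound 3 to compound 4 (within the scatter) for this swap. The ester also matches the other two side chains, with no change at the digits printed from compound 2 to compound 4 (within the scatter) and no change at the digits printed from compound 1 to compound 4 (within the scatter) as the steps that link them, so this ester joins the carboxy, nitrile and diethylamide side chains at one shared level. That is all these numbers establish, and nothing measured here explains why such different side chains read alike.

The compounds shown leave open whether any group at this place can move the number at all, for example a primary amine at the end of the chain, a longer chain or a side chain carrying a phenyl ring. They also leave open whether a hydroxy group in place of a methoxy group on the shared core would lift these compounds off this common level.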